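Fluoro for Chloro on the Cyano-Bearing Ring

The source may hold more compounds than are shown below. What is called first, only, known or untested is meant among the compounds shown, and "the series" means these compounds.

In a functional assay on HEK293 cells for antagonist activity at metabotropic glutamate receptor 5 (Rattus norvegicus), read by calcium flux (on this read-out higher numbers stand for weaker inhibition and lower numbers for stronger inhibition), compound 3 `Cc1cccc(C#Cc2cc(Cl)cc(C#N)c2)n1` gives 1.22 nM, the second highest of the three numbers shown. Its nearest neighbour is compound 1 `Cc1nc(C#Cc2cc(F)cc(Br)c2)cs1` with 1.11 nM, a gap within the scatter, while compound 2 `Cc1cccc(C#Cc2cc(C#N)cc([N+](=O)[O-])c2)n1` gives 3.68 nM. Among the measured compounds shown here, the only resolved step, a 3.0-fold lower number from compound 2 to compound 3 (0.48 log units; beyond the scatter), exchanges chloro for nitro and does not touch the change at hand. Compound 4 `Cc1cccc(C#Cc2cc(F)cc(C#N)c2)n1` differs from compound 3 by fluoro in place of chloro on an aromatic carbon. For the measured compounds named here, no measured pair exchanges one halogen for another, so no step bears on it directly; still, compound 1, which also carries fluoro, gives 1.11 nM, close to compound 3, which points to a small change. Compound 4 is therefore expected at 1.8 nM (range 0.7 nM to 5 nM), a step of a 1.5-fold higher number from compound 3 to compound 4 (0.17 log units; within the scatter) expected to stay within the scatter.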

Compound 4, half-maximal inhibitory concentration: 1.22 nM
For compound 4 the middle estimate is 1.5-fold (0.17 log units) above the measured one; measured number inside the range.
By their numbers in this assay, from the lowest: compounds 1, 3 and 4 (each within the scatter of the next); then compound 2.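

In this assay, the place meta to a cyano group takes fluoro as well as chloro, with no change at the digits printed from compound 3 to compound 4 (within the scatter) for this first direct exchange of one halogen for another. Nitro at the same place gives the higher number, with a 3.0-fold lower number from compound 2 to compound 4 (0.48 log units; beyond the scatter) marking a modest gain for fluoro over nitro. No measurement shown explains why the two halogens match.

Still open, going by these compounds, is whether an amine or a carboxylic acid at this place would keep the number as low as either halogen does. Also open, on these data alone, is whether the match between fluoro and chloro holds on a different core.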